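A few compounds are considered here, and "the series" means these few. Any claim that something is new, unique, unknown or untested is made for them only; others in the source may bear on it.

Measured in a functional assay on HL-60 cells (Homo sapiens) for inhibition; on this read-out higher numbers stand for weaker inhibition and lower numbers for stronger inhibition:
Compound 1 `COc1cc(/C=C\c2cn(C)c3ccccc23)cc(OC)c1OC`: 3090 nM
Compound 2 `COc1cc(/C=C/c2ccc3ccccc3c2)cc([N+](=O)[O-])c1OC`: > 10000 nM, a limit
Compound 3 `COc1cc(/C=C\c2ccc3ccccc3c2)cc([N+](=O)[O-])c1OC`: 340 nM

Compound 2 gives > 10000 nM in this assay, which is a limit of the assay and not a number. On these data alone, it therefore stands at the limit of > 10000 nM in this assay, at which 1 of the 3 values shown sits, and its true position is unknown.

Compound 4 `COc1cc(/C=C/c2ccc3ccccc3c2)cc(NC(C)=O)c1OC` has not yet been measured. It keeps the double bond drawn E, as in compound 2. The change lies elsewhere: acetamido in place of nitro on an aromatic carbon. This is acetamido in place of nitro on an aromatic carbon, ortho to a methoxy group.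

Within the data shown here, only one measured step starts from compound 2. This is an at least 29-fold lower number from compound 2 to compound 3 (1.46 log units; beyond the scatter), a large step, and it concerns (the fact that compounds 2 and 3 differ only in the configuration as drawn). Among the measured compounds shown here, that step moves the double bond from E to Z and leaves the nitro group in place, so no measured step shows what replacing the nitro group does. Compound 4 does not make the move to Z that accompanied the large drop in an at least 29-fold lower number from compound 2 to compound 3 (1.46 log units; beyond the scatter), so it is expected to stay close to compound 2 and a report at the limit is the likeliest outcome.

The expected change is a number no higher from compound 2 to compound 4 (the limit leaves the size open), with no step beyond the scatter anticipated. The estimate for compound 4 is 10000 nM, with an expected range of 3000 nM to 30000 nM.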

Compound 4, half-maximal inhibitory concentration: 2880 nM
For compound 4 the middle estimate is 3.5-fold (0.54 log units) above the measured one; the whole stated range lies above it.
By their numbers in this assay, from the lowest: compound 3; then compounds 4 and 1 (each within the scatter of the next). At a limit, above all of these: compound 2.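

In this assay, among these compounds, the earlier compounds showed a change only at the double bond, whereas here the double bond stays drawn E and acetamido in place of nitro, on an aromatic carbon ortho to a methoxy group, gives an at least 3.4-fold lower number from compound 2 to compound 4 (0.54 log units; beyond the scatter). This is the first sign that the group at this position matters on its own, and that a lower number can be reached from compound 2 without the move from E to Z. Compound 2 stands at a limit and not at a number, so the true size of this step stays open: the limit of > 10000 nM in this assay, at which 1 of the 4 values shown sits.

The compounds shown leave open whether acetamido in place of nitro would have a similar effect with the double bond drawn Z, and they give no cause for the step seen with the double bond drawn E. They also leave open what other groups on this aromatic carbon would give, such as an amine, which would show whether the acetamido group as a whole is needed, or a carboxylic acid.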